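A few compounds are considered here, and "the series" means these few. Any claim that something is new, unique, unknown or untested is made for them only; others in the source may bear on it.

Measured compounds:
compound 1, `COc1ccc(C2=NOC(c3ccc(C)cc3)C2S(=O)(=O)CC2=NCCO2)cc1`, 71.3%
compound 2, `COc1ccc(C2=NOC(c3ccc(C)cc3)C2S(=O)(=O)CC2=NCCS2)cc1`, 59.6%
compound 3, `O=S(=O)(CC1=NCCS1)C1=NNCC1c1ccc(Cl)cc1`, reported as "not active" (no number reported)

In a functional assay, read by Griess assay, with a stated time of 150 min, tested at 100 ug/mL (on this read-out lower numbers stand for a weaker effect and higher numbers for a stronger effect at the one concentration tested), compound 1 gives 71.3% and compound 2 gives 59.6%. These two share a core and differ in one place: a group of 5 heavy atoms (3 carbon, 1 nitrogen, 1 oxygen; one five-membered non-aromatic ring with 2 hetero atoms) in place of a group of 5 heavy atoms (3 carbon, 1 nitrogen, 1 sulfur; one five-membered non-aromatic ring with 2 hetero atoms), on a saturated chain carbon bound to a sulfonyl sulfur. That change gives a number 11.7 percentage points higher from compound 2 to compound 1 (beyond the scatter).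

Compound 3, `O=S(=O)(CC1=NCCS1)C1=NNCC1c1ccc(Cl)cc1`, carries a different core; how its core differs from that of compound 2 is not broken down here. In this assay, going by the values given here, compound 3 is reported as "not active" (no number reported), and no number is given for it, so no step from compound 2 to compound 3 can be sized.

Compound 4, `O=S(=O)(CC1=NCCO1)C1=NNCC1c1ccc(Cl)cc1`, has not yet been tested in this assay. It differs from compound 3 by a group of 5 heavy atoms (3 carbon, 1 nitrogen, 1 oxygen; one five-membered non-aromatic ring with 2 hetero atoms) in place of a group of 5 heavy atoms (3 carbon, 1 nitrogen, 1 sulfur; one five-membered non-aromatic ring with 2 hetero atoms), on a saturated chain carbon bound to a sulfonyl sulfur. This is the same change, at the same place, as from compound 2 to compound 1, and there it produced a number 11.7 percentage points higher from compound 2 to compound 1 (beyond the scatter). Whether a step of similar size would appear on the core of compound 3 is not shown by the compounds measured so far, since compound 3 itself has no number. Because compound 3 is reported as "not active" (no number reported), compound 4 is expected to remain weak in this assay, with a fair chance that it too is reported without a number. The estimate for compound 4 in this assay is 15%, expected to lie between 0% and 40%.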

Compound 4, a percentage reported as activity, at one concentration (the size of the read-out at that concentration, not a potency): "not active" (no number reported)
No number was reported for compound 4, and the estimate cannot be compared.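

In this assay, going by these compounds alone, compound 3 and compound 4 are both reported as not active, with no number for either, so no step between them can be read. Nothing measured here bears on this result. The compounds shown leave open whether the change that gave a number 11.7 percentage points higher from compound 2 to compound 1 (beyond the scatter) has any measurable effect on the core of compound 3.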